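This account rests on a few compounds, and the source may have more. Where it says the series, first, only, none or still open, it means among the compounds named here.

Of the compounds shown here, two have been measured in a functional assay on A549 cells (Homo sapiens) for cytotoxicity, read by MTT assay, with a stated time of 48 h; a lower number here means a stronger inhibitor, a higher number a weaker inhibitor. Compound 1 `O=C(CC1c2ccccc2N=C(SCCCCCN2CCCC2)N1c1ccc(-c2ccc(F)cc2)cc1)NCc1ccc(F)cc1` gives 12600 nM in this assay. Compound 2 `CN(C)CCCCCSC1=Nc2ccccc2C(CC(=O)NCc2ccc(F)cc2)N1c1ccccc1` gives 36800 nM in this assay, which is the highest of the two numbers; the gap to compound 1 lies beyond the usual scatter of repeated measurements. Compound 3 `CN(C)CCCCCSC1=Nc2ccccc2C(CC(=O)NCc2ccc(F)cc2)N1c1ccc(-c2ccc(F)cc2)cc1` has not yet been measured. It differs from compound 2 in one place: 4-fluorophenyl in place of hydrogen on an aromatic carbon. Among the compounds with values here, the same 4-fluorophenyl is present in compound 1, which however also differs from compound 2 elsewhere, so the two measured values cannot be read as a step for this one change; they show only that the compound carrying the 4-fluorophenyl gave the lower number. Within the data shown here, no single-change step has been measured; the expectation therefore rests on those two values alone. Compound 3 is expected to move toward the number of compound 1, a modest step downward from compound 2 that may reach beyond the scatter, with a 2.3-fold lower number from compound 2 to compound 3 (0.36 log units; beyond the scatter). Compound 3 is estimated at 16000 nM, with a range from 6000 nM to 40000 nM.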

Compound 3, half-maximal inhibitory concentration: 11300 nM
The estimate for compound 3 lay 1.4-fold (0.15 log units) above the measured number, within the range that was stated.
By their numbers in this assay, from the lowest: compounds 3 and 1 (each within the scatter of the next); then compound 2.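

In this assay, within the data shown here, the swap of hydrogen for 4-fluorophenyl on an aromatic carbon, para to a large group, gives a 3.3-fold lower number from compound 2 to compound 3 (0.51 log units; beyond the scatter), and this is the first reading of that change alone, since the earlier pair of compounds differed in two places. This modest step beyond the scatter shows that, with the dimethylamino end of the chain held fixed, the number in this cell assay responds to what sits at this position. The second new comparison, dimethylamino in place of pyrrolidin-1-yl on a saturated chain carbon, five bonds along the chain from a sulfur, gives a 1.1-fold lower number from compound 1 to compound 3 (0.05 log units; within the scatter), so these two chain ends cannot be told apart here when the 4-fluorophenyl is present.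

Going by these compounds, whether the fluorine on the added ring matters remains open, as does what a plain phenyl, a single chlorine or a methoxy group would give at this position, or a morpholine at the end of the chain. Nothing available explains why the added ring goes with the lower number.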